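Replacing the Carbonyl Substituent Across Two Related Cores

The source may report more compounds than this note shows. Statements on the series, on what has been measured and on what is new or still open speak of the compounds shown alone.

Compound 1 `COc1cc(N(C)CCN(C)C)c(NC(=O)C=C(C)C)cc1Nc1nc2c(c(-c3cn(C)c4ccc(F)cc34)n1)CSCC2` carries a 2-methylprop-1-en-1-yl group on a carbonyl carbon whose other neighbour is an amide-type nitrogen, and in a functional assay on A549 cells (Homo sapiens) for inhibition, read by MTT assay, with a stated time of 72 h (a lower number here means a stronger inhibitor, a higher number a weaker inhibitor), compound 1 gives 902 nM. Compound 2 `C/C=C\C(=O)Nc1cc(Nc2nc3c(c(-c4cn(C)c5ccc(F)cc45)n2)CSCC3)c(OC)cc1N(C)CCN(C)C` differs from it in one place: prop-1-en-1-yl in place of 2-methylprop-1-en-1-yl on a carbonyl carbon. This change produced a 5.9-fold higher number from compound 1 to compound 2 (0.77 log units; beyond the scatter), and in this assay compound 2 gives 5310 nM.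

Compound 3 `COc1cc(N(C)CCN(C)C)c(NC(=O)C=C(C)C)cc1Nc1nc2c(c(-c3cn(C)c4ccccc34)n1)CS(=O)(=O)CC2` keeps the 2-methylprop-1-en-1-yl group but rests on a different core; the difference between the two cores is not broken down here. In this assay compound 3 gives 787 nM, a number within the scatter of compound 1 and well apart from compound 2.

Compound 4 `C/C=C\C(=O)Nc1cc(Nc2nc3c(c(-c4cn(C)c5ccccc45)n2)CS(=O)(=O)CC3)c(OC)cc1N(C)CCN(C)C` has not been measured. It stands to compound 3 as compound 2 stands to compound 1: prop-1-en-1-yl in place of 2-methylprop-1-en-1-yl on a carbonyl carbon. The place is the same in both pairs, a carbonyl carbon whose other neighbour is an amide-type nitrogen, so it is the same change, occurring for the second time among these four compounds.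

Going by the values given here, the single measured precedent is a 5.9-fold higher number from compound 1 to compound 2 (0.77 log units; beyond the scatter). Compound 1 and compound 3 give numbers within the scatter of each other, and on that footing the change is expected to carry over to the second core with a similar outcome. The expected step is therefore a 5.1-fold higher number from compound 3 to compound 4 (0.71 log units; beyond the scatter). Compound 4 is estimated at 4000 nM in this assay. Among the compounds with values here, its likely range is expected to run from 1500 nM to 12000 nM, wide because a 5.9-fold higher number from compound 1 to compound 2 (0.77 log units; beyond the scatter) is the only example of this change measured so far.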

Compound 4, half-maximal inhibitory concentration: 4260 nM
Beside the measured number, compound 4's estimate is 1.1-fold (0.03 log units) below it, within the range that was stated.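

The replacement of 2-methylprop-1-en-1-yl by prop-1-en-1-yl on a carbonyl carbon was read a second time in this assay, as a 5.4-fold higher number from compound 3 to compound 4 (0.73 log units; beyond the scatter), and this step agrees in direction and size with the one seen on the first core: the same change on two cores in this assay, a 5.9-fold higher number (0.77 log units; beyond the scatter) from compound 1 to compound 2 and a 5.4-fold higher number (0.73 log units; beyond the scatter) from compound 3 to compound 4, 1.1-fold (0.04 log units) apart, within the scatter of two such steps. Within these four compounds, then, the change carried from one core to the other, and the step on the core of compound 1 was a sound guide to the step on the core of compound 3. This does not show that the change would behave the same way on any further core or in any other assay, and two pairs from one cell assay cannot tell why the number rises when this group is exchanged.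

The compounds shown hold only these two groups on the carbonyl carbon, so it remains open how the number would move with a plain ethenyl group, or with a longer chain ending in a dimethylamino group. On these data alone, the cores of compound 1 and compound 3 also differ in more than one place, and it remains open how each of those differences would bear on the step if taken alone.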